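Amide nitrogen variation on a shared core, paw edema read-out

A few compounds are considered here, and "the series" means these few. Any claim that something is new, unique, unknown or untested is made for them only; others in the source may bear on it.

Measured compounds:
compound 1, `CCCCNC(=O)CC1CCc2cc(OC)c(OC)cc21`, 31.3%
compound 2, `COc1cc2c(cc1OC)C(CC(=O)NC1CCCC1)CC2`, 40.6%

In a functional assay on the whole organism (strain Wistar) for inhibition, with Rattus norvegicus as the target, read by paw edema, with stated times of 60 min and 1 h, at a dose of 100 mg/kg by the oral route (on this read-out lower numbers stand for less inhibition and higher numbers for more inhibition at the one dose given (going by the name of the read-out)), compound 1 gives 31.3%, and compound 2 gives 40.6%. For the measured compounds named here, the single measured step, a number 9.3 percentage points higher from compound 1 to compound 2 (within the scatter), came with cyclopentyl in place of butyl on an amide-type nitrogen and lies within the scatter. Compound 2 carries the higher of the two numbers shown, but its gap to compound 1 is within the scatter, so no order between the two can be read.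

Compound 3, `COc1cc2c(cc1OC)C(CC(=O)N1CCCC1)CC2`, is not yet measured. It differs from compound 2 as follows: pyrrolidin-1-yl in place of cyclopentylamino on a carbonyl carbon. Going by the values given here, the one measured step bears on it only loosely: it changed the group on the amide-type nitrogen while keeping the amide hydrogen, and it stayed within the scatter. Among the compounds with values here, no measured step removes that hydrogen or closes the nitrogen into a ring, so no direction can be drawn from the data. The expected step is a number 5.6 percentage points lower from compound 2 to compound 3 (within the scatter), that is, none beyond the scatter. Compound 3 is therefore estimated at 35%, with a range from 15% to 58%.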

Compound 3, a percentage reported as inhibition, in the whole organism at one dose (the size of the read-out at that dose, not a potency): 4.69%
The estimate for compound 3 lay 30.3 percentage points above the measured number; measured number below the stated range.
By their numbers in this assay, from the lowest: compound 3; then compounds 1 and 2 (each within the scatter of the next).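

In this assay, pyrrolidin-1-yl in place of cyclopentylamino on a carbonyl carbon gives a number 35.9 percentage points lower from compound 2 to compound 3 (beyond the scatter) and pyrrolidin-1-yl in place of butylamino gives a number 26.6 percentage points lower from compound 1 to compound 3 (beyond the scatter) while the earlier change of the group on that nitrogen, with the amide hydrogen kept, gave only a number 9.3 percentage points higher from compound 1 to compound 2 (within the scatter) and stayed within the scatter. The position is therefore not indifferent to every change: among these three compounds, the two that keep the amide hydrogen show no order between them, and the one that lacks it, with the nitrogen closed into a ring, stands clearly lowest. No measurement shown here explains this drop.

Losing the amide hydrogen and closing the ring at the nitrogen happen together in compound 3, so the compounds shown cannot separate the two changes. An open-chain diethylamino group on the same carbonyl carbon would lack the amide hydrogen without the ring, and a pyrrolidin-3-ylamino or piperidin-1-yl group would test other ring forms on the shared core.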